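The compounds below may be only part of what the source reports. "The series", "measured", "known", "first", "only" and "open" are said of these compounds alone.

In a functional assay on HT-29 cells (Homo sapiens) for cytotoxicity, read by sulforhodamine B assay (a lower number here means a stronger inhibitor of growth, a higher number a weaker inhibitor of growth), compound 1 `CC1=CC[C@@H]([C@@](C)(O)CCCC(C)(C)NC=S)CC1` gives 11400 nM, compound 2 `CC1=CC[C@@H]([C@@](C)(O)CCCC(C)(C)NC(=S)N/N=C\c2ccc(C)cc2)CC1` gives 10400 nM and compound 3 `COc1ccc(/C=N\NC(=S)NC(C)(C)CCC[C@](C)(O)[C@@H]2CC=C(C)CC2)cc1` gives 7420 nM. All three values lie within the scatter of one another, so compound 3 stands level with compound 1 and compound 2. Compound 4 `CC1=CC[C@@H]([C@@](C)(O)CCCC(C)(C)NC(=S)N/N=C\c2ccc([N+](=O)[O-])cc2)CC1` differs from compound 3 at one place: nitro in place of methoxy on an aromatic carbon, para to a large group. Among the compounds with values here, the only measured step at this place is a 1.4-fold lower number from compound 2 to compound 3 (0.15 log units; within the scatter), methoxy in place of methyl, and it stays within the scatter. Within the data shown here, no measured compound carries nitro, so no direction can be favoured and no step beyond the scatter is expected. The expected change is a 1.1-fold higher number from compound 3 to compound 4 (0.03 log units; within the scatter), within the scatter. For compound 4 the estimated value is 8000 nM, with an expected range of 3500 nM to 15000 nM.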

Compound 4, concentration for 50% growth inhibition: 12300 nM
Estimate against measurement, compound 4: 1.5-fold (0.19 log units) below; the range from low to high includes it.
By their numbers in this assay, from the lowest: compounds 3, 2, 1 and 4 (each within the scatter of the next).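

In this assay nitro in place of methoxy gives a 1.7-fold higher number from compound 3 to compound 4 (0.22 log units; within the scatter) and nitro in place of methyl gives a 1.2-fold higher number from compound 2 to compound 4 (0.07 log units; within the scatter) so the first nitro at this place adds no step beyond the scatter. On an aromatic carbon para to a large group, methyl, methoxy and nitro therefore stand level, and no order among them can be drawn. Nothing at hand explains why this change leaves the number level. Going by these compounds, whether an amine, a carboxylic acid or a longer chain at this place would move the number beyond the scatter stays open.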